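Dipropylamino in place of (4-ethylphenyl)amino in compound 1

This account rests on a few compounds, and the source may have more. Where it says the series, first, only, none or still open, it means among the compounds named here.

Measured in a functional assay on MCF7 cells (Homo sapiens) for inhibition, read by sulforhodamine B assay; a lower number here means a stronger inhibitor, a higher number a weaker inhibitor:
compound 1 `CCc1ccc(NC2=CC(=O)c3nc4n(c3C2=O)[C@H]2OC[C@@H](O)[C@H]2OC4)cc1`: 960 nM
compound 2 `CCOc1ccc(NC2=CC(=O)c3nc4n(c3C2=O)[C@H]2OC[C@@H](O)[C@H]2OC4)cc1`: 1430 nM
compound 3 `O=C1C=C(Nc2ccc(C(F)(F)F)cc2)C(=O)c2c1nc1n2[C@H]2OC[C@@H](O)[C@H]2OC1`: > 4000 nM (a limit)

Among the measured compounds shown here, compound 1 and compound 2 hold the only exact numbers, and these are not separated: a 1.5-fold higher number from compound 1 to compound 2 (0.17 log units; within the scatter). The other steps are an at least 4.1-fold higher number from compound 1 to compound 3 (0.61 log units; beyond the scatter) and an at least 2.7-fold higher number from compound 2 to compound 3 (0.44 log units; beyond the scatter), both resting on (the limit of > 4000 nM in this assay, at which 1 of the 3 values shown sits).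

Compound 4 `CCCN(CCC)C1=CC(=O)c2nc3n(c2C1=O)[C@H]1OC[C@@H](O)[C@H]1OC3` replaces the whole group: dipropylamino in place of (4-ethylphenyl)amino on a double-bonded ring carbon. The aromatic ring and the hydrogen-bond donor leave with it. The measured steps only alter a substituent on that ring, so they bear on this change indirectly. Still, one such swap gave an at least 4.1-fold higher number from compound 1 to compound 3 (0.61 log units; beyond the scatter), so a modest move to a higher number in this assay is expected. The expected size is a 2.6-fold higher number from compound 1 to compound 4 (0.42 log units; beyond the scatter). Compound 4 is estimated at 2500 nM, with an expected range of 800 nM to 6000 nM.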

Compound 4, half-maximal inhibitory concentration: > 16000 nM
Compound 4 was reported as a limit (the forecaster's own chance of this, stated with the estimate: 30%); middle value at least 6.4-fold (0.80 log units) from the limit.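

Dipropylamino in place of (4-ethylphenyl)amino on the double-bonded ring carbon gives an at least 16-fold higher number from compound 1 to compound 4 (1.22 log units; beyond the scatter) in this assay. Compound 4 reads > 16000 nM, which is a limit. The earlier steps shown here altered only a substituent on the aromatic ring, whereas here the ring and the hydrogen-bond donor leave together, and this open-chain amine does not keep the potency of compound 1.

Which of the two losses matters remains open. Propylamino, which keeps the donor without the ring, and methyl(phenyl)amino, which keeps the ring without the donor, would separate them.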